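The source may hold more compounds than are shown below. What is called first, only, known or untested is meant among the compounds shown, and "the series" means these compounds.

Compound 1 `CNc1nc(NCCCN(C)C)c2sc(-c3ccc(C(C)=O)cc3)cc2n1` carries a 4-acetylphenyl group on the shared core; in a physicochemical assay for solubility, in phosphate buffer, at pH 6.5 (on this read-out lower numbers stand for lower solubility and higher numbers for higher solubility), compound 1 gives 12.5 ug/mL. Compound 2 `CNc1nc(NCCCN(C)C)c2sc(-c3ccc(N4CCNCC4)cc3)cc2n1` gives 12.5 ug/mL, so the step of no change at the digits printed from compound 1 to compound 2 (within the scatter) lies within the scatter. Compound 3 `CNc1nc(NCCCN(C)C)c2sc(-c3ccc(C(F)(F)F)cc3Cl)cc2n1` sits at the limit of the assay, > 100 ug/mL, so no number is read there (the limit of > 100 ug/mL in this assay, at which 1 of the 3 values shown sits). Compound 4 `CNc1nc(NCCCN(C)C)c2sc(-c3cccc(C#N)c3)cc2n1` differs from compound 1 as follows: 3-cyanophenyl in place of 4-acetylphenyl on an aromatic carbon. Within the data shown here, no measured step covers an exchange of this kind; the one step known, from compound 1 to compound 2, shows no change. A small rise is expected for compound 4, so the step of a 2.0-fold higher number from compound 1 to compound 4 (0.30 log units; within the scatter) is an estimate only. Compound 4 is therefore expected to give 25 ug/mL, with a range from 8 ug/mL to 100 ug/mL.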

Compound 4, solubility: 25 ug/mL
Beside the measured number, compound 4's estimate shows no gap at the digits printed; the range from low to high includes it.
By their numbers in this assay, from the lowest: compounds 1, 2 and 4 (each within the scatter of the next). At a limit, above all of these: compound 3.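

In this assay, 3-cyanophenyl in place of 4-acetylphenyl on the aromatic carbon next to the ring sulfur gives a 2.0-fold higher number from compound 1 to compound 4 (0.30 log units; within the scatter). Alongside no change at the digits printed from compound 1 to compound 2 (within the scatter), this is a second exchange at this position that stays within the scatter, now with a nitrile in place of the carbonyl-bearing group. Compound 3 remains the only compound at a limit, which is not a number: the limit of > 100 ug/mL in this assay, at which 1 of the 4 values shown sits.

Still open, on these data alone, is whether a carboxylic acid on the phenyl ring at this position would move the read-out beyond the scatter. The compounds shown also leave open which part of the 2-chloro-substituted trifluoromethyl group of compound 3 separates it from the others.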